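Aryl variation on the shared core: methyl to fluoro

The source may report more compounds than this note shows. Statements on the series, on what has been measured and on what is new or still open speak of the compounds shown alone.

Three compounds share one core and differ only in the aryl group attached to it. Compound 1 `Nc1cccc(-c2cn3nc(-c4cccs4)sc3n2)c1` carries thiophen-2-yl; in a functional assay on FM3A cells (Mus musculus) for inhibition, read by cell counting, with a stated time of 2 days (on this read-out lower numbers stand for stronger inhibition and higher numbers for weaker inhibition), compound 1 gives > 250000 nM, which is a limit of the assay and not a number. Compound 2 `CCOc1ccc(-c2nn3cc(-c4cccc(N)c4)nc3s2)cc1` carries 4-ethoxyphenyl; in this assay compound 2 gives >= 250000 nM, again a limit rather than a number. Among the compounds with values here, compound 3 `Cc1ccc(-c2nn3cc(-c4cccc(N)c4)nc3s2)cc1` carries 4-methylphenyl and in this assay gives 5800 nM, the only number among the three. Both measured steps run toward compound 3: an at least 43-fold lower number from compound 1 to compound 3 (1.63 log units; beyond the scatter) and an at least 43-fold lower number from compound 2 to compound 3 (1.63 log units; beyond the scatter). Each starts from a limit (the limit of > 250000 nM in this assay, at which 1 of the 3 values shown sits, (the limit of >= 250000 nM in this assay, at which 1 of the 3 values shown sits)), and the true size of each is known only as a bound.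

Compound 4 `Nc1cccc(-c2cn3nc(-c4ccc(F)cc4)sc3n2)c1` is not yet measured. It differs from compound 3 in one place: fluoro in place of methyl on an aromatic carbon. Neither measured step exchanges methyl for fluoro; both bear on it only loosely. The step from compound 2 to compound 3 shows that the group in this position can shift the read-out by a large amount, and the step from compound 1 to compound 3 shows that the whole aryl matters. Within the data shown here, no measured pair tells which way fluoro goes. The step from compound 3 to compound 4 is expected to be a 3.4-fold higher number from compound 3 to compound 4 (0.54 log units; beyond the scatter), with wide uncertainty. Compound 4 is expected to give about 20000 nM in this assay, within 4000 nM to 150000 nM.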

Compound 4, half-maximal inhibitory concentration: 33000 nM
The estimate for compound 4 lay 1.7-fold (0.22 log units) below the measured number, and the stated range covers the measured number.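

In this assay, a 5.7-fold higher number from compound 3 to compound 4 (0.76 log units; beyond the scatter), so the exchange of methyl for fluoro on the six-membered aromatic ring now has a direction and a size, with both ends of the step being numbers and not bounds. Against the 4-ethoxyphenyl compound, 4-fluorophenyl still lowers the number, an at least 7.5-fold lower number from compound 2 to compound 4 (0.87 log units; beyond the scatter), and this step is only a bound since it starts from the limit of compound 2: the limit of >= 250000 nM in this assay, at which 1 of the 4 values shown sits. Against the thiophen-2-yl compound the picture is the same, an at least 7.5-fold lower number from compound 1 to compound 4 (0.87 log units; beyond the scatter), and this step too is only a bound since it starts from the limit of compound 1: the limit of > 250000 nM in this assay, at which 1 of the 4 values shown sits.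

Among the para groups shown, methyl gives the lowest number, fluoro a higher one and ethoxy only a limit, which leaves open where chloro, a hydroxyl, an amine or a longer chain such as propyl would fall on this carbon. Also open, on these data alone, is whether the gap between methyl and fluoro persists once the amine on the other aryl group of the shared core is changed.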